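The compounds below may be only part of what the source reports. "The series", "measured", "known", "first", "only" and "open" are said of these compounds alone.

Measured so far in a functional assay on KARPAS-422 cells (Homo sapiens) for inhibition, read by luminescence and CellTiter-Glo, with a stated time of 14 days; on this read-out higher numbers stand for weaker inhibition and lower numbers for stronger inhibition:
- compound 1 `Cc1ncccc1-c1cnc(NCc2c(F)ccc3c2CCO3)c2cn[nH]c(=O)c12` at 39.8 nM
- compound 2 `CNC(=O)c1ccc(-c2cnc(NCc3c(F)ccc4c3CCO4)c3cn[nH]c(=O)c23)c(C)n1` at 12.6 nM

Compound 2 holds the lower of the two numbers, at 12.6 nM in this assay, and is the better inhibitor of the pair. Compound 3 `Cc1nc(C(=O)N(C)C)ccc1-c1cnc(NCc2c(F)ccc3c2CCO3)c2cn[nH]c(=O)c12` alters it in one place: methyl in place of hydrogen on an amide-type nitrogen, which is methyl in place of hydrogen on an amide-type nitrogen, or methylcarbamoyl to dimethylcarbamoyl.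

Among the compounds with values here, only one measured step bears on this, and only indirectly: a 3.2-fold lower number from compound 1 to compound 2 (0.50 log units; beyond the scatter), with methylcarbamoyl in place of hydrogen on an aromatic carbon. Within the data shown here, no measured compound shows what a change on the amide-type nitrogen does, so the direction is open. Compound 3 keeps a carbonyl-bearing group in the place where the modest step of a 3.2-fold lower number from compound 1 to compound 2 (0.50 log units; beyond the scatter) was seen, so part of that gain is expected to remain, with a slight drift towards weaker inhibition as the likelier direction. The expected change is a 1.6-fold higher number from compound 2 to compound 3 (0.20 log units; within the scatter), probably within the scatter. For compound 3 the estimated value is 20 nM, with an expected range from 7 nM to 55 nM in this assay.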

Compound 3, half-maximal inhibitory concentration: 31.6 nM
The estimate for compound 3 lay 1.6-fold (0.20 log units) below the measured number; measured number inside the range.
By their numbers in this assay, from the lowest: compound 2; then compounds 3 and 1 (each within the scatter of the next).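

In this assay, within the data shown here, the amide-type nitrogen proves sensitive to a single added methyl: going from methylcarbamoyl to dimethylcarbamoyl gives a 2.5-fold higher number from compound 2 to compound 3 (0.40 log units; beyond the scatter), a loss that the earlier compounds could not reveal. Measured against the compound with hydrogen on the aromatic carbon, dimethylcarbamoyl gives a 1.3-fold lower number from compound 1 to compound 3 (0.10 log units; within the scatter), so the gain seen with methylcarbamoyl, a 3.2-fold lower number from compound 1 to compound 2 (0.50 log units; beyond the scatter), does not carry over to the dimethylcarbamoyl group, and the carbonyl-bearing group alone does not secure it in this pair of amides. Nothing available gives a reason for this loss.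

Open, as far as these compounds go, is how the number responds to the unsubstituted carbamoyl group, with both hydrogens on the nitrogen, and to a longer chain on that nitrogen, such as ethylcarbamoyl, which would show whether methylcarbamoyl sits near a limit or whether dimethylcarbamoyl differs for the lost amide hydrogen alone. Also open, from the compounds shown here alone, is whether an amide is needed at all on this aromatic carbon, a question that a carboxylic acid, a nitrile or a small amine there would address.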